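This account rests on a few compounds, and the source may have more. Where it says the series, first, only, none or still open, it means among the compounds named here.

Measured in a functional assay on HepG2 cells (Homo sapiens) for antiproliferative activity, read by MTT assay, with a stated time of 72 h; a higher number here means a weaker inhibitor, a lower number a stronger inhibitor:
- Compound 1 (`O=C1COc2ccc(-c3cnc4ccccc4c3)cc2N1C1CCCCC1`) gives > 40000 nM, a limit
- Compound 2 (`COc1ncc(-c2ccc3c(c2)N(C2CC2)C(=O)CO3)cc1NS(=O)(=O)c1ccc(F)cc1`) gives 14400 nM

The reading for compound 1 is a limit of the assay and not a number (the limit of > 40000 nM in this assay, at which 1 of the 2 values shown sits). Going by the values given here, compound 2 does give a number, but no measured step connects it to the other compounds, so the series offers no direct guide to the size of the next change.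

Compound 3 (`O=C1COc2ccc(-c3cnc4ccccc4c3)cc2N1c1ccc(Cl)cc1`) keeps the core of compound 1 and carries 4-chlorophenyl in place of cyclohexyl on an amide-type nitrogen in a ring. In this assay, a small step toward stronger inhibition is expected, though compound 3 may also return only a limit. The expectation stays modest because compound 1 offers > 40000 nM as its starting point, and that reading is a limit. The estimated change is an at least 1.3-fold lower number from compound 1 to compound 3 (0.12 log units; that floor lies within the scatter). For compound 3 the estimated value is 30000 nM, with an expected range from 12000 nM to 70000 nM.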

Compound 3, half-maximal inhibitory concentration: 32700 nM
Beside the measured number, compound 3's estimate is 1.1-fold (0.04 log units) below it, within the range that was stated.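

In this assay compound 3 gives 32700 nM, which shows that this amide-type nitrogen in a ring can carry a group that returns a number, here 4-chlorophenyl in place of cyclohexyl. Compound 1 gives > 40000 nM, a limit and not a number. The change can therefore be read only as an at least 1.2-fold lower number from compound 1 to compound 3 (0.08 log units; that floor lies within the scatter), so its true size stays unknown, its floor does not separate the pair from the scatter, and the series still has one reading that gives no number: the limit of > 40000 nM in this assay, at which 1 of the 3 values shown sits.

Still open, on these data alone, is whether the step belongs to the aromatic ring or to the chlorine, a question that phenyl without chlorine on the same nitrogen would address, and whether 4-methoxyphenyl or an aminoethyl chain at that place would give a lower number than compound 3. Going by these compounds alone, compound 2 has no step connecting it to compound 1 or compound 3, so its value offers no guide to how far this position can move the number on the shared core.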